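A few compounds are considered here, and "the series" means these few. Any claim that something is new, unique, unknown or untested is made for them only; others in the source may bear on it.

Compound 1 `O=S(=O)(/C=C/c1ccc(F)cc1)Cc1ccc(Nc2ncnc3ccccc23)cc1`: 10 nM
Compound 2 `COc1cc2ncnc(Nc3ccc(CS(=O)(=O)/C=C/c4ccc(Cl)cc4Cl)cc3)c2cc1OC`: 15000 nM

In a functional assay on ACHN cells (Homo sapiens) (a higher number here means a weaker inhibitor of growth, a lower number a stronger inhibitor of growth), compound 2 has the higher of the two numbers at 15000 nM, and compound 1 gives 10 nM. The gap between these two compounds lies far beyond the scatter. Compound 3 `COc1cc2ncnc(Nc3ccc(CS(=O)(=O)/C=C/c4ccc(Br)cc4)cc3)c2cc1OC` has not yet been measured. It departs from compound 2 in one place: 4-bromophenyl in place of 2,4-dichlorophenyl on a double-bonded chain carbon bound to a double-bonded chain carbon. The change puts 4-bromophenyl in place of 2,4-dichlorophenyl, and the rest of the structure stays as it is in compound 2. For the measured compounds named here, no step between measured compounds shows what such a change does in this assay, so the expectation stays close to compound 2 at 15000 nM. A moderate move toward a lower number is expected, with the estimate being a 3.8-fold lower number from compound 2 to compound 3 (0.57 log units; beyond the scatter). The uncertainty is wide. For compound 3 the estimated value is 4000 nM, with an expected range of 500 nM to 20000 nM.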

Compound 3, concentration for 50% growth inhibition: 4000 nM
For compound 3 middle estimate and measured number coincide at the digits printed; measured number inside the range.
By their numbers in this assay, from the lowest: compound 1; then compound 3; then compound 2.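

In this assay, for the compounds shown here, this is the first step at the place on a double-bonded chain carbon bound to a double-bonded chain carbon, and it shows that the group there can shift growth inhibition: 4-bromophenyl in place of 2,4-dichlorophenyl gives a 3.8-fold lower number from compound 2 to compound 3 (0.57 log units; beyond the scatter) and the step is modest, though beyond the scatter. The change alters the halogen and the number of halogen atoms together, so this one step does not separate the two. No measurement shown gives a cause for the step.

The compounds shown leave open whether 4-chlorophenyl at this place would read closer to compound 2 or to compound 3, which would begin to divide the step between the two alterations. As far as these compounds go, compound 1 differs from both in more than one place, so the contribution of this group to its number also remains open.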